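Ester in place of amide: an expected outcome

This account rests on a few compounds, and the source may have more. Where it says the series, first, only, none or still open, it means among the compounds named here.

Measured so far:
Compound 1, `CCn1nnc(-c2sc(-c3cccc(N)c3)nc2O)n1`, in an assay on HEK293 cells for inhibition of transient receptor potential cation channel subfamily M member 8 (Homo sapiens), read by FLIPR, with stated times of 5 min and 3 min (on this read-out lower numbers stand for stronger inhibition and higher numbers for weaker inhibition), gives 61 nM.
Compound 2, `CCNC(=O)c1sc(-c2ccccc2)nc1O`, in this assay reaches only a limit of the assay, > 100000 nM.

Compound 2 thus sits at the limit of > 100000 nM in this assay, at which 1 of the 2 values shown sits, without a number of its own. Compound 3, `CCOC(=O)c1sc(-c2ccccc2)nc1O`, differs from compound 2 in one place: ethoxy in place of ethylamino on a carbonyl carbon. For the measured compounds named here, no pair of measured compounds shows what this change does, so the expectation rests on compound 2 alone. A step from compound 2 to compound 3 of a number no higher from compound 2 to compound 3 (the limit leaves the size open) is expected, that is none beyond the scatter. Compound 3 is estimated at 100000 nM, probably again a limit, within 20000 nM to 300000 nM.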

Compound 3, half-maximal inhibitory concentration: 32 nM
Estimate against measurement, compound 3: 3100-fold (3.49 log units) above; the whole stated range lies above it.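

Ethoxy in place of ethylamino on a carbonyl carbon gives an at least 3100-fold lower number from compound 2 to compound 3 (3.49 log units; beyond the scatter) in this assay, so this position responds very strongly to a change of a single linking atom. Compound 2 has no number of its own and stands at a limit, so the step gives only a minimum size: the limit of > 100000 nM in this assay, at which 1 of the 3 values shown sits.

The compounds shown cannot tell whether losing the amide hydrogen or gaining the oxygen matters more. On these data alone, how a carboxylic acid, a dimethylamino group or a longer chain such as propoxy would read on this carbonyl carbon also stays open.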